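The source may hold more compounds than are shown below. What is called first, only, known or untested is meant among the compounds shown, and "the series" means these compounds.

The measured compounds and their numbers:

Compound 1, `Cn1cc(-c2ccc(NC(=O)c3cn(CC4CCCCC4)cc(-c4ccc(F)cc4)c3=O)cc2)c2c(N)ncnc21`, gives 2.3 nM in an assay on isolated protein for inhibition of tyrosine-protein kinase receptor UFO (Homo sapiens), read by ELISA; a lower number here means a stronger inhibitor, a higher number a weaker inhibitor.
Compound 2, `Cn1cc(-c2ccc(NC(=O)c3cn(CC4CCOCC4)cc(-c4cccc(F)c4)c3=O)cc2)c2c(N)ncnc21`, gives 3 nM in this assay.
Compound 3, `Cn1cc(-c2ccc(NC(=O)c3cn(CC4CCOCC4)cc(-c4ccc(F)cc4)c3=O)c(Cl)c2)c2c(N)ncnc21`, gives 3.7 nM in this assay.

Compound 1 has the lowest of the three numbers, but the gaps to compound 2 and to compound 3 both lie within the usual scatter, so the three are best read as equally strong inhibitors. All three carry a six-membered saturated ring attached through a one-carbon chain to the aromatic nitrogen of the shared core.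

Compound 4, `Cn1cc(C(=O)Nc2ccc(-c3cn(C)c4ncnc(N)c34)cc2)c(=O)c(-c2ccc(F)cc2)c1`, has not yet been measured in this assay. It differs from compound 1 in one place: hydrogen in place of cyclohexyl on a saturated chain carbon bound to an aromatic nitrogen. For the measured compounds named here, no measured pair shows this change, so there is no direct guide to its effect. Since every measured compound keeps a saturated ring at this position, the expectation for compound 4 is a loss of potency beyond the scatter, with the step of a 13-fold higher number from compound 1 to compound 4 (1.12 log units; beyond the scatter) estimated as a moderate rise in the number. Compound 4 is therefore expected to give about 30 nM, most likely between 5 nM and 200 nM.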

Compound 4, half-maximal inhibitory concentration: 5 nM
For compound 4 the middle estimate is 6.0-fold (0.78 log units) above the measured one; measured number inside the range.
By their numbers in this assay, from the lowest: compounds 1, 2, 3 and 4 (each within the scatter of the next, the first and the last beyond it).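

In this assay, hydrogen in place of cyclohexyl on a saturated chain carbon bound to an aromatic nitrogen gives a 2.2-fold higher number from compound 1 to compound 4 (0.34 log units; beyond the scatter) and this step is modest, even though six heavy atoms leave. The earlier compounds shown here all carried a saturated ring here, whereas compound 4 gives 5 nM with only a methyl, so strong inhibition does not depend on that ring. Why so large a cut costs so little cannot be said from any measurement available here.

Going by these compounds, only the two ends of this change can be compared directly, so it stays open how a chain of intermediate length, such as ethyl or propyl, would behave at this place. On these data alone, it is equally open what a chain ending in an amine or a carboxylic acid would do to the number.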